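Sulfonyl aryl variation on the shared core of compound 1

The compounds below may be only part of what the source reports. "The series", "measured", "known", "first", "only" and "open" are said of these compounds alone.

Measured compounds:
compound 1 `COc1ccc(S(=O)(=O)N2CCN(c3nc(N)c4cc(OC)c(OC)cc4n3)CC2)cc1` — 39000 nM
compound 2 `COc1cc2nc(N3CCN(S(=O)(=O)c4cc(F)c(Cl)c(C(=O)O)c4)CC3)nc(N)c2cc1OC` — 56000 nM
compound 3 `COc1cc2nc(N3CCN(S(=O)(=O)c4cccc5ccccc45)CC3)nc(N)c2cc1OC` — 14000 nM

All three share one core and differ only in the aryl group on the sulfonyl sulfur. In a functional assay on PC-3 cells (Homo sapiens) for inhibition (a lower number here means a stronger inhibitor, a higher number a weaker inhibitor), compound 1 gives the second highest of the three numbers; compound 2 sits within the scatter of it, and compound 3 gives the lowest number of the set. The change from compound 1 to compound 4 `COc1cc2nc(N3CCN(S(=O)(=O)c4ccc(-c5ccc(S(C)(=O)=O)cc5)cc4)CC3)nc(N)c2cc1OC` is 4-(methylsulfonyl)phenyl in place of methoxy on an aromatic carbon.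

Among the measured compounds shown here, no measured step makes this exact change, so the expectation rests on neighbouring ones. The step of a 1.4-fold higher number from compound 1 to compound 2 (0.16 log units; within the scatter) shows that swapping the aryl for a small, polar-substituted phenyl left the number essentially unchanged. The step of a 2.8-fold lower number from compound 1 to compound 3 (0.44 log units; beyond the scatter) shows that a larger aromatic group in place of the methoxyphenyl brought a modest lowering, and a 4.0-fold lower number from compound 2 to compound 3 (0.60 log units; beyond the scatter) points the same way. Compound 4 also carries a larger aromatic extension at the para position, so a modest lowering of the number is expected, roughly as seen from compound 1 to compound 3, but with wide uncertainty given that the added group differs.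

The estimated step is a 2.0-fold lower number from compound 1 to compound 4 (0.29 log units; within the scatter). For compound 4 the expected value in this assay is 20000 nM, with a range from 7000 nM to 60000 nM.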

Compound 4, half-maximal inhibitory concentration: 7200 nM
Compound 4: middle estimate off by 2.8-fold (0.44 log units), on the high side, within the range that was stated.
By their numbers in this assay, from the lowest: compounds 4 and 3 (each within the scatter of the next); then compounds 1 and 2 (each within the scatter of the next).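

In this assay, 4-(methylsulfonyl)phenyl in place of methoxy on an aromatic carbon gives a 5.4-fold lower number from compound 1 to compound 4 (0.73 log units; beyond the scatter), a step beyond the scatter. This shows that the position, para to a large group, accepts a much larger substituent, with 10 heavy atoms entering for 2 and an extra six-membered aromatic ring of carbon only, and that the number falls rather than rises. Compound 4 also lies within the scatter of compound 3, so the biaryl sulfonyl group and the naphthalen-1-yl group cannot be ranked in this assay, and nothing shown gives a measured reason for the step.

The compounds shown do not separate the contribution of the added ring from that of the methylsulfonyl group on it, and a plain phenyl at this carbon would be the direct comparison. They also leave open how the number responds to other groups on the outer ring, such as an amine, a carboxylic acid or a nitrile, or to a longer chain between the two rings.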